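The source may hold more compounds than are shown below. What is called first, only, known or untested is meant among the compounds shown, and "the series" means these compounds.

Within the data shown here, compound 2 `COc1ccc(NS(=O)(=O)c2cc(Cl)cc(Cl)c2)cc1N1CCN(C)CC1` in an assay on HeLa cells for binding affinity to 5-hydroxytryptamine receptor 6 (Homo sapiens) (a higher number here means a weaker inhibitor, a lower number a stronger inhibitor), gives 2 nM, the lowest of the two numbers so far; compound 1 `COc1ccc(NS(=O)(=O)c2cccc([N+](=O)[O-])c2)cc1N1CCN(C)CC1` gives 79.4 nM. Among the measured compounds shown here, the one step that bears on the aryl on the sulfonyl sulfur, a 40-fold lower number from compound 1 to compound 2 (1.60 log units; beyond the scatter), shows that substitution on that ring can move the number strongly. Compound 3 `COc1ccc(NS(=O)(=O)c2cc(I)ccc2C)cc1N1CCN(C)CC1` differs from compound 2 by 5-iodo-2-methylphenyl in place of 3,5-dichlorophenyl on a sulfonyl sulfur. For the measured compounds named here, no measured step covers iodine or a methyl on this ring, so the direction is open; with a ring that still carries a halogen entering, a step within or only modestly beyond the scatter is expected, a 2.5-fold higher number from compound 2 to compound 3 (0.40 log units; beyond the scatter). Compound 3 is therefore estimated at 5 nM, range 1.5 nM to 20 nM.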

Compound 3, inhibition constant: 1 nM
The estimate for compound 3 lay 5.0-fold (0.70 log units) above the measured number, and the stated range ends above it.
By their numbers in this assay, from the lowest: compounds 3 and 2 (each within the scatter of the next); then compound 1.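

In this assay, 5-iodo-2-methylphenyl on the sulfonyl sulfur cannot be told apart from 3,5-dichlorophenyl (a 2.0-fold lower number from compound 2 to compound 3 (0.30 log units; within the scatter)). Against 3-nitrophenyl, the same ring gives a large step (a 79-fold lower number from compound 1 to compound 3 (1.90 log units; beyond the scatter)), so the large step is not confined to 3,5-dichlorophenyl. No measurement at hand explains either step.

From the compounds shown here alone, the separate roles of the iodine and the methyl stay open, as these two groups enter together in compound 3. Also open, going by these compounds, is how an amine or a carboxylic acid on this ring would read.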